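Sulfanyl for Chloro on a Fused Purine-Like Core

The source may report more compounds than this note shows. Statements on the series, on what has been measured and on what is new or still open speak of the compounds shown alone.

In a functional assay on WI-38 cells (Homo sapiens) for inhibition (a higher number here means a weaker inhibitor, a lower number a stronger inhibitor), the three measured compounds stand as follows.
Compound 1, `CC(=O)OC(C)n1cnc2c(Cl)nc(N)nc21`, gives only a limit, > 500000 nM.
Compound 2, `CC(=O)OCCOn1cnc2c(Cl)nc(N)nc21`, gives only a limit, > 500000 nM.
Compound 3, `CC(=O)OC(C)n1cnc2c(S)nc(N)nc21`, gives 400 nM.

Compound 1 and compound 2 share the fused core and the chloro group on it, and the difference between the two cores is not broken down here; both sit at the limit of > 500000 nM in this assay, at which 2 of the 3 values shown sit. Compound 3 differs from compound 1 in one place only, (sulfanyl in place of chloro on an aromatic carbon), and this single change made an at least 1200-fold lower number from compound 1 to compound 3 (3.09 log units; beyond the scatter). Because compound 1 sits at the limit of > 500000 nM in this assay, at which 2 of the 3 values shown sit, the true size of that step is known only as a lower bound.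

Compound 4, `CC(=O)OCCOn1cnc2c(S)nc(N)nc21`, is not yet measured. It stands to compound 2 as compound 3 stands to compound 1: sulfanyl in place of chloro on an aromatic carbon, at a place described in the same words in both pairs, so this is the same change made on the other side chain. Its size is expected to be comparable to an at least 1200-fold lower number from compound 1 to compound 3 (3.09 log units; beyond the scatter), which rests on a single measured pair and on compound 2 sitting only at the limit of > 500000 nM in this assay, at which 2 of the 3 values shown sit. In this assay the step from compound 2 to compound 4 is therefore expected to be an at least 620-fold lower number from compound 2 to compound 4 (2.79 log units; beyond the scatter). Compound 4 is estimated at 800 nM, with a plausible range from 150 nM to 8000 nM, the lower-end side chain effect seen between compound 1 and compound 2 being unknown.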

Compound 4, half-maximal inhibitory concentration: > 500000 nM
Compound 4: only a limit was reported (the forecaster's own chance of this, stated with the estimate: 15%); at least 620-fold (2.79 log units) between middle value and limit.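

In this assay compound 4 gives only a limit, > 500000 nM. Compound 2 gives only a limit as well, so the step between the two cannot be read: the limit of > 500000 nM in this assay, at which 3 of the 4 values shown sit.

The compounds shown leave open whether sulfanyl in place of chloro on an aromatic carbon changes the number at all in the pair of compound 2 and compound 4.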